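The source may report more compounds than this note shows. Statements on the series, on what has been measured and on what is new or still open speak of the compounds shown alone.

In a functional assay on MKN-45 cells (Homo sapiens) for antiproliferative activity, read by CellTiter-Glo, with a stated time of 3 days (a lower number here means a stronger inhibitor, a higher number a weaker inhibitor), three compounds have been measured. Compound 1 `COc1ccc(Cl)c([C@@H](C)Oc2c(N)ncc3c(-c4cnn(C5CCNCC5)c4)coc23)c1Cl` gives 1600 nM, compound 2 `CC(=O)N1CCC(n2cc(-c3coc4c(O[C@H](C)c5c(Cl)ccc(F)c5Cl)c(N)ncc34)cn2)CC1` gives 670 nM, and compound 3 `C[C@@H](Oc1c(N)ncc2c(-c3ccccn3)coc12)c1c(Cl)ccc(F)c1Cl` gives 4600 nM. Compound 3 therefore stands highest of the three, and both other compounds lie lower by more than the usual scatter.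

Compound 4 `C[C@@H](Oc1c(N)ncc2c(C3=CCN(C(=O)N(C)C)CC3)coc12)c1c(Cl)ccc(F)c1Cl` differs from compound 3 in one group, on an aromatic carbon of a five-membered aromatic ring with 1 oxygen: a group of 11 heavy atoms (8 carbon, 2 nitrogen, 1 oxygen; one six-membered non-aromatic ring with 1 hetero atom) in place of a group of 6 heavy atoms (5 carbon, 1 nitrogen; one six-membered aromatic ring with 1 hetero atom), on an aromatic carbon. Among the measured compounds shown here, no pair of measured compounds isolates this change, so any forecast rests on thin evidence. The closest guide is compound 2, which also carries a six-membered non-aromatic ring in its group at this place and gives 670 nM. On that single comparison, a number lower than that of compound 3 is expected. The expected change is a 3.1-fold lower number from compound 3 to compound 4 (0.49 log units; beyond the scatter), a moderate step towards stronger inhibition. For compound 4 the estimated value is 1500 nM, with an expected range of 400 nM to 4500 nM.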

Compound 4, half-maximal inhibitory concentration: 510 nM
Beside the measured number, compound 4's estimate is 2.9-fold (0.47 log units) above it; measured number inside the range.
By their numbers in this assay, from the lowest: compounds 4 and 2 (each within the scatter of the next); then compound 1; then compound 3.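

In this assay, replacing pyridin-2-yl with the larger group holding a six-membered non-aromatic ring gives a 9.0-fold lower number from compound 3 to compound 4 (0.96 log units; beyond the scatter). This shows that the place on an aromatic carbon of the five-membered aromatic ring with 1 oxygen tolerates this much larger group, and that the number falls with it. Compound 2 gives 670 nM and compound 4 gives 510 nM, within the scatter of each other, so two differently built groups that each carry a six-membered non-aromatic ring give matching results, though no measurement here accounts for the step.

The compounds shown do not separate the contributions of the ring, its double bond and the dimethylurea unit. Going by these compounds, whether a plain piperidin-4-yl group or a morpholine ring at this place would give a similar number also remains open.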